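From aminomethyl to triazolylmethyl on a shared indolyl core

The source may report more compounds than this note shows. Statements on the series, on what has been measured and on what is new or still open speak of the compounds shown alone.

Of the compounds shown here, two have been measured in an assay on isolated protein for inhibition of Myeloperoxidase (Homo sapiens); a higher number here means a weaker inhibitor, a lower number a stronger inhibitor. Compound 1 `CN(C)Cc1ccc(-n2cc(-c3ccc4cc[nH]c4c3)c3c(Cl)ccnc32)cc1` gives 2600 nM. Compound 2 `NCc1ccc(-n2cc(-c3ccc4cc[nH]c4c3)c(C(F)(F)F)n2)cc1` gives 360 nM, the lowest of the two numbers; its nearest neighbour is compound 1, whose number is higher by a margin beyond the usual scatter. For the measured compounds named here, no single-point step between the two measured compounds can be drawn, as they differ in several places at once.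

Compound 3 `FC(F)(F)c1nn(-c2ccc(Cc3nc[nH]n3)cc2)cc1-c1ccc2cc[nH]c2c1` is compound 2 with 1H-1,2,4-triazol-3-yl in place of amino on a saturated chain carbon bound to an aromatic carbon. Going by the values given here, no measured pair illustrates this change, so the expected size of the step rests on the two numbers alone. The step is expected to be small, likely a modest weakening that may not exceed the scatter, as a 1.8-fold higher number from compound 2 to compound 3 (0.26 log units; within the scatter). Compound 3 is therefore estimated at 650 nM, with a plausible range from 150 nM to 2800 nM.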

Compound 3, half-maximal inhibitory concentration: 23000 nM
The estimate for compound 3 lay 35-fold (1.55 log units) below the measured number; measured number outside the range, above it.
By their numbers in this assay, from the lowest: compound 2; then compound 1; then compound 3.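

At this position, on a saturated chain carbon bound to an aromatic carbon, the change from amino to 1H-1,2,4-triazol-3-yl is far from neutral: in this assay it brings a 64-fold higher number from compound 2 to compound 3 (1.81 log units; beyond the scatter). For the compounds shown here, this is the first comparison here that differs in one place only, and it shows that the number responds strongly to the group at this position, even though the hydrogen-bond donor count and the absence of net charge stay the same. Nothing measured here accounts for the size of this step.

One step cannot tell whether the loss belongs to the triazole ring in particular or would follow any replacement of amino. Also open, as far as these compounds go, is how a carboxylic acid, a tetrazole or a longer aminoethyl chain would read at this place.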